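A few compounds are considered here, and "the series" means these few. Any claim that something is new, unique, unknown or untested is made for them only; others in the source may bear on it.

Working notes on the series built on the shared core of compound 1 (`COc1ccc(NC(=O)NCCNS(=O)(=O)c2ccc(-c3ccccc3OCc3ccccc3)s2)cc1`). In a functional assay on RS4-11 cells (Homo sapiens) for inhibition, read by CCK-8 assay, with a stated time of 48 h (on this read-out higher numbers stand for weaker inhibition and lower numbers for stronger inhibition), compound 1 gives > 20000 nM as its result, which is a limit of the assay and not a number. In this assay compound 2 (`O=[N+]([O-])c1cccc(NC(=S)NCCNS(=O)(=O)c2ccc(-c3ccccc3OCc3ccccc3)s2)c1`) gives 11600 nM and compound 3 (`O=[N+]([O-])c1cccc(NC(=S)NCCNS(=O)(=O)c2ccc(-c3ccccc3OCc3cccc(O)c3)s2)c1`) gives 9800 nM as their results. Among the measured compounds shown here, these two values lie within the scatter of each other, so compound 3 stands level with compound 2, and they are the only two numbers in hand.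

Compound 4 (`COc1ccc(NC(=O)NCCNS(=O)(=O)c2ccc(-c3ccccc3OCc3cccc(O)c3)s2)cc1`) follows from compound 3 by one change: a group of 11 heavy atoms (8 carbon, 1 nitrogen, 2 oxygen; one six-membered aromatic ring of carbon only) in place of a group of 12 heavy atoms (7 carbon, 2 nitrogen, 2 oxygen, 1 sulfur; one six-membered aromatic ring of carbon only), on an amine nitrogen with (4-methoxyphenyl)carbamoyl entering on an amine nitrogen.

For the measured compounds named here, two measured steps bear on this. The same exchange of groups ran the opposite way in an at least 1.7-fold lower number from compound 1 to compound 2 (0.23 log units; that floor lies within the scatter) and is known there only as a floor. Hydroxy in place of hydrogen gave a 1.2-fold lower number from compound 2 to compound 3 (0.07 log units; within the scatter) and so offers no ground for a separate allowance. Reversing the first step, a higher number is expected in this assay, modest in size and possibly reported only as a limit. The expected step is a 1.9-fold higher number from compound 3 to compound 4 (0.29 log units; within the scatter) as estimated here. For compound 4 the estimated value is 19000 nM with an expected range from 10000 nM to 40000 nM in this read-out.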

Compound 4, half-maximal inhibitory concentration: 9400 nM
The estimate for compound 4 lay 2.0-fold (0.31 log units) above the measured number; measured number below the stated range.
By their numbers in this assay, from the lowest: compounds 4, 3 and 2 (each within the scatter of the next). At a limit, above all of these: compound 1.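

On the core carrying the hydroxy group, (4-methoxyphenyl)carbamoyl in place of the group of 12 heavy atoms on the amine nitrogen produces no readable shift in this assay, a 1.0-fold lower number from compound 3 to compound 4 (0.02 log units; within the scatter), and this exchange is now read without a limit on one side: the same change on two cores in this assay, an at least 1.7-fold lower number (0.23 log units; that floor lies within the scatter) from compound 1 to compound 2 and a 1.0-fold higher number (0.02 log units; within the scatter) from compound 4 to compound 3; the limit leaves it open whether they differ. The hydroxy group on an aromatic carbon, which earlier gave only a step within the scatter, now has a step that clears it, an at least 2.1-fold lower number from compound 1 to compound 4 (0.32 log units; beyond the scatter), though the two readings of that change cannot yet be set against each other: the same change on two cores in this assay, a 1.2-fold lower number (0.07 log units; within the scatter) from compound 2 to compound 3 and an at least 2.1-fold lower number (0.32 log units; beyond the scatter) from compound 1 to compound 4; the limit leaves it open whether they differ. The result for compound 1 is a limit of the assay and not a number: the limit of > 20000 nM in this assay, at which 1 of the 4 values shown sits.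

Still open, on these data alone, is whether the exchange on the amine nitrogen and the hydroxy group act differently on the two cores, as no number exists for compound 1 to settle it. Also open, as far as these compounds go, is whether a carboxylic acid or an amine in place of hydroxy, or a longer chain on the amine nitrogen, would give a step beyond the scatter from compound 4.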